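The source may hold more compounds than are shown below. What is called first, only, known or untested is meant among the compounds shown, and "the series" means these compounds.

Measured compounds:
compound 1, `Cc1nc(N)sc1CCCN/C(N)=N/C(=O)NC(c1ccccc1)C(C)C`: 35.5 nM
compound 2, `Cc1nc(N)sc1CCCN/C(N)=N/C(=O)N[C@@H](C)c1ccccc1`: 51.3 nM
compound 3, `Cc1nc(N)sc1CCCN/C(N)=N/C(=O)NC(C)c1cccs1`: 63.1 nM

In an assay on membranes from Sf9 cells for displacement of a labelled ligand from histamine H2 receptor (Homo sapiens), read by scintillation counting, with a stated time of 60 min (a lower number here means a stronger inhibitor, a higher number a weaker inhibitor), compound 3 gives the highest of the three numbers, but none of the three stands apart: the nearest, compound 2, and the furthest, compound 1, both lie within the usual scatter of compound 3. Within the data shown here, the only measured step that changes one place is a 1.2-fold higher number from compound 2 to compound 3 (0.09 log units; within the scatter), which swaps a 1-phenylethyl for a 1-(thiophen-2-yl)ethyl on an amide-type nitrogen without moving the number beyond the scatter.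

Compound 4, `Cc1nc(N)sc1CCCN/C(N)=N/C(=O)NCc1ccccc1`, has not yet been measured. It differs from compound 3 by benzyl in place of 1-(thiophen-2-yl)ethyl on an amide-type nitrogen. This change has two parts: the five-membered ring goes back to a six-membered ring of carbon only, which is the reverse of the measured step and therefore expected to change little, and the methyl branch on the carbon joined to that nitrogen is removed. Among the measured compounds shown here, no measured pair shows the loss of that branch; compound 1 and compound 2, which differ only in the size of the branch, give values close to each other. The expected step is therefore small, a 1.4-fold lower number from compound 3 to compound 4 (0.15 log units; within the scatter), with no clear direction beyond the scatter. The estimate for compound 4 is 45 nM, between 20 nM and 110 nM.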

Compound 4, inhibition constant: 69.2 nM
The estimate for compound 4 lay 1.5-fold (0.19 log units) below the measured number; low and high end bracket the measured number.
By their numbers in this assay, from the lowest: compounds 1, 2, 3 and 4 (each within the scatter of the next).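

In this assay, among these compounds, the branch on the saturated chain carbon can now be judged directly, which the earlier compounds did not allow: hydrogen in place of methyl gives a 1.3-fold higher number from compound 2 to compound 4 (0.13 log units; within the scatter) and hydrogen in place of isopropyl gives a 1.9-fold higher number from compound 1 to compound 4 (0.29 log units; within the scatter) as its step. Neither branch is therefore needed to keep the number in this range, and even the larger isopropyl group leaves compound 4 within the scatter of compound 1. Changing the ring and removing the branch together, in the swap of 1-(thiophen-2-yl)ethyl for benzyl on the amide-type nitrogen, gives a 1.1-fold higher number from compound 3 to compound 4 (0.04 log units; within the scatter) and so also stays within the scatter, while no outside information explains this flat picture.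

All four groups on this nitrogen carry an aromatic ring, so the compounds shown leave open what a plain n-butyl chain would do there, or a phenyl ring bearing an amine or a carboxylic acid. They also leave open whether a 2-phenylethyl group, with its longer chain, would stay within the scatter of benzyl in compound 4.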